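A few compounds are considered here, and "the series" means these few. Any claim that something is new, unique, unknown or untested is made for them only; others in the source may bear on it.

Working notes on the series.

Compound 1 `CCCCc1nc(N)c2nc(O)n(Cc3ccccc3)c2n1` gives 0.03 uM in a functional assay (spleen, spleen) for activation, with Mus musculus as the target; a lower number here means that less compound is needed, a higher number that more compound is needed for the effect. Compound 2 `CCCCNc1nc(N)c2nc(O)n(Cc3ccccc3)c2n1` gives 1 uM, and compound 3 `Nc1nc(S)nc2c1nc(O)n2Cc1ccccc1` gives 10 uM. Compound 3 thus stands at the highest of the three numbers: the step of a 330-fold higher number from compound 1 to compound 3 (2.52 log units; beyond the scatter) is large, the step of a 10-fold higher number from compound 2 to compound 3 (1.00 log units; beyond the scatter) is modest, and the step of a 33-fold higher number from compound 1 to compound 2 (1.52 log units; beyond the scatter) separates the other two.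

Compound 4 `CCCC[S+]([O-])c1nc(N)c2nc(O)n(Cc3ccccc3)c2n1` differs from compound 3 in one place: a group of 6 heavy atoms (4 carbon, 1 oxygen, 1 sulfur; no ring) in place of one sulfur atom, on an aromatic carbon.

Going by the values given here, two measured steps bear on this change. Both run toward the sulfanyl of compound 3 and both raise the number, the butyl case by a 330-fold higher number from compound 1 to compound 3 (2.52 log units; beyond the scatter) and the butylamino case by a 10-fold higher number from compound 2 to compound 3 (1.00 log units; beyond the scatter). Compound 4 moves away from the sulfanyl and brings a four-carbon chain back onto the same aromatic carbon, so a step to a lower number, beyond the scatter, is expected, though the group entering is not butyl itself and nothing measured tells how far the return goes. The expected step is a 33-fold lower number from compound 3 to compound 4 (1.52 log units; beyond the scatter). For compound 4 the estimate is 0.3 uM, within a range of 0.03 uM to 3 uM.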

Compound 4, minimum effective concentration: 0.01 uM
Estimate against measurement, compound 4: 30-fold (1.48 log units) above; the whole stated range lies above it.
By their numbers in this assay, from the lowest: compound 4; then compound 1; then compound 2; then compound 3.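

At the aromatic carbon between two ring nitrogen atoms, the group of 6 heavy atoms in place of sulfanyl gives the largest step seen so far in this assay (a 1000-fold lower number from compound 3 to compound 4 (3.00 log units; beyond the scatter)). The same group also stands well ahead of butylamino (a 100-fold lower number from compound 2 to compound 4 (2.00 log units; beyond the scatter)) and goes past butyl itself (a 3.0-fold lower number from compound 1 to compound 4 (0.48 log units; beyond the scatter)), a modest step but beyond the scatter, so butyl no longer marks the low end at this position and a four-carbon chain carrying sulfur and oxygen is tolerated there. Nothing measured on these compounds explains this order.

How the step divides between the sulfur and the oxygen stays open, as butylsulfanyl and butylsulfonyl are not among the compounds shown. Also open, going by these compounds, is how a longer chain or a terminal carboxylic acid would read at this carbon.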